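This account rests on a few compounds, and the source may have more. Where it says the series, first, only, none or still open, it means among the compounds named here.

Measured compounds:
- compound 1 `O=S(=O)(CC1=NCCS1)C1=NNCC1c1ccccc1`: in a functional assay, read by Griess assay, with a stated time of 150 min, tested at 75 ug/mL (a lower number here means a weaker effect, a higher number a stronger effect of the compound at the concentration tested), compound 1 gives "not active" (no number reported)
- compound 2 `Cc1ccc(C2CNN=C2S(=O)(=O)CC2=NCCO2)cc1`: in this assay compound 2 gives 49.7%
- compound 3 `O=S(=O)(CC1=NCCO1)C1=NNCC1c1ccc(Cl)cc1`: in this assay compound 3 gives "not active" (no number reported)

Compound 2 is the only entry in this assay with a number attached; compound 1 and compound 3 come back only as not active. Compound 2 therefore stands alone as the reference point, and nothing in the measured set ranks it against a second number.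

Compound 4 `Cc1ccc(C2CNN=C2S(=O)(=O)CC2=NCCS2)cc1` is not yet measured. Against compound 2 the change is a group of 5 heavy atoms (3 carbon, 1 nitrogen, 1 sulfur; one five-membered non-aromatic ring with 2 hetero atoms) in place of a group of 5 heavy atoms (3 carbon, 1 nitrogen, 1 oxygen; one five-membered non-aromatic ring with 2 hetero atoms), on a saturated chain carbon bound to a sulfonyl sulfur. Going by the values given here, no step between two measured compounds isolates this change, so its size cannot be read from the data. Among the compounds with values here, compound 1 carries the entering ring and was reported as not active, but compound 1 also differs from compound 2 elsewhere, so its result gives only a hint and no measured step.

The expectation for this assay is a fall from compound 2, likely beyond the scatter, with a real chance that compound 4 is reported as not active without a number. Compound 4 is estimated at 28%, ranging from 5% to 52%, an expected step of a number 21.7 percentage points lower from compound 2 to compound 4 (beyond the scatter).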

Compound 4, a percentage reported as activity, at one concentration (the size of the read-out at that concentration, not a potency): 48.6%
Compound 4: the middle estimate sits 20.6 percentage points below what was measured, within the range that was stated.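

In this assay, going by these compounds alone, the sulfur-containing five-membered ring can stand in place of the oxygen-containing one, on a saturated chain carbon bound to a sulfonyl sulfur, with a number 1.1 percentage points lower from compound 2 to compound 4 (within the scatter); this is the first reading of this change with the rest of the molecule held fixed. Compound 1 carries the same sulfur-containing ring and gives "not active" (no number reported), whereas compound 4 gives 48.6%, so a report of no activity does not follow from that ring alone, and the earlier hint against it does not hold for compound 4. The data offer no measurement that explains why the two rings read alike in this assay.

Steps to compound 1 and compound 3 cannot be read, as neither compound carries a number, so what separates them from the active pair stays unsized. The compounds shown also leave open whether this position tolerates anything further from these two rings, such as a morpholine or an open-chain amine on the same carbon, since the comparison so far covers a single exchange of oxygen for sulfur at one concentration.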